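This account rests on a few compounds, and the source may have more. Where it says the series, first, only, none or still open, it means among the compounds named here.

Compound 2 `N#Cc1ccc(-c2csc(N3N=C(c4ccc(N5CCCCC5)cc4)CC3c3ccc(Cl)cc3)n2)cc1` in a functional assay on A549 cells (Homo sapiens) for antiproliferative activity, read by MTT assay, with a stated time of 72 h (a lower number here means a stronger inhibitor, a higher number a weaker inhibitor), gives 11200 nM. Compound 1 `Clc1ccc(C2CC(c3ccc(N4CCCCC4)cc3)=NN2c2nc(-c3ccccc3)cs2)cc1` in this assay gives 64200 nM.

Within the data shown here, compound 2 stands lowest of the two measured compounds, with compound 1 the only neighbour. Compound 3 `COc1ccc(-c2csc(N3N=C(c4ccc(N5CCCCC5)cc4)CC3c3ccc(Cl)cc3)n2)cc1` differs from compound 2 by methoxy in place of cyano on an aromatic carbon. Among the measured compounds shown here, the only step that bears on this position is a 5.7-fold lower number from compound 1 to compound 2 (0.76 log units; beyond the scatter), which shows that the group at this place matters. For the measured compounds named here, no measured step exchanges cyano for methoxy, so the direction is uncertain; a modest move back toward compound 1 is expected. Compound 3 is therefore estimated at 25000 nM (range 8000 nM to 70000 nM), a step of a 2.2-fold higher number from compound 2 to compound 3 (0.35 log units; beyond the scatter) expected from compound 2.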

Compound 3, half-maximal inhibitory concentration: > 100000 nM
Compound 3 gave a limit, no number (the forecaster's own chance of this, stated with the estimate: 10%); at least 4.0-fold (0.60 log units) between middle value and limit.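

In this assay, compound 3 reads only as a limit and not as a number: the limit of > 100000 nM in this assay, at which 1 of the 3 values shown sits.

With methoxy in place of cyano, the result is an at least 8.9-fold higher number from compound 2 to compound 3 (0.95 log units; beyond the scatter), so the gain seen with cyano does not carry over to methoxy at this place. With methoxy in place of hydrogen, the result is an at least 1.5-fold higher number from compound 1 to compound 3 (0.19 log units; that floor lies within the scatter), so methoxy shows no gain over hydrogen here.

Going by these compounds, how a carboxylic acid or an amine would read at this place stays open. So does whether the lower number of compound 2 is particular to cyano.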